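Swapping the Oxazole Arm for an Isopropyl Pyrazole

This account rests on a few compounds, and the source may have more. Where it says the series, first, only, none or still open, it means among the compounds named here.

Three close relatives have been measured in a functional assay on HCT-116 cells (Homo sapiens) for inhibition; on this read-out lower numbers stand for stronger inhibition and higher numbers for weaker inhibition. Compound 1 `CCCNCc1cc(-c2c(C(=O)NCC)noc2-c2cc(C(C)C)c(O)cc2O)on1` gives 117 nM, compound 2 `C=CNCc1cc(-c2c(C(=O)NCC)noc2-c2cc(C(C)C)c(O)cc2O)on1` gives 121 nM, and compound 3 `CCNC(=O)c1noc(-c2cc(C(C)C)c(O)cc2O)c1-c1cc(C(=O)NC)no1` gives 124 nM. Compound 3 carries the highest of the three numbers, but its nearest neighbour compound 2 sits only a 1.0-fold higher number from compound 2 to compound 3 (0.01 log units; within the scatter) away and compound 1 only a 1.1-fold higher number from compound 1 to compound 3 (0.03 log units; within the scatter) away, so the three are indistinguishable within the usual scatter.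

Compound 4 `CCNC(=O)c1noc(-c2cc(C(C)C)c(O)cc2O)c1-c1cnn(C(C)C)c1` departs from compound 3 by a single change: 1-isopropyl-1H-pyrazol-4-yl in place of 3-(methylcarbamoyl)-1,2-oxazol-5-yl on an aromatic carbon. The measured steps that touch the same part of the molecule are a 1.1-fold higher number from compound 1 to compound 3 (0.03 log units; within the scatter) and a 1.0-fold higher number from compound 2 to compound 3 (0.01 log units; within the scatter), both of which alter the substituent on that five-membered ring while keeping the ring itself. Neither moves the read-out beyond the scatter, and a 1.0-fold higher number from compound 1 to compound 2 (0.01 log units; within the scatter) likewise shows that varying the group on the amine nitrogen changes nothing. Going by the values given here, no measured step replaces the whole ring as compound 4 does, so the present change reaches further than anything tested. The expectation is therefore a step of a 1.6-fold higher number from compound 3 to compound 4 (0.21 log units; within the scatter) in this assay, with a wide allowance for surprise in either direction. Compound 4 is estimated at 200 nM, with a likely range from 60 nM to 700 nM.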

Compound 4, half-maximal inhibitory concentration: 21 nM
The estimate for compound 4 lay 9.5-fold (0.98 log units) above the measured number; measured number below the stated range.
By their numbers in this assay, from the lowest: compound 4; then compounds 1, 2 and 3 (each within the scatter of the next).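

Across the earlier compounds, altering the group carried by the oxazole ring at this position left the number in this assay unmoved, whereas replacing the whole arm with 1-isopropyl-1H-pyrazol-4-yl gives a 5.9-fold lower number from compound 3 to compound 4 (0.77 log units; beyond the scatter) and is the only kind of change here that goes beyond the scatter. The replacement reads much the same against the two amine-bearing arms, with a 5.8-fold lower number from compound 2 to compound 4 (0.76 log units; beyond the scatter) and a 5.6-fold lower number from compound 1 to compound 4 (0.75 log units; beyond the scatter) as its steps, so the gain does not depend on which of the three oxazole arms is removed, and the entering arm shows that a hydrogen-bond donor on this arm is not needed for the stronger inhibition. No measurement offered here explains why the number falls.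

The ring and its substituent change together, so these compounds cannot say whether the pyrazole ring or the isopropyl group accounts for the step. A methyl group or a longer chain in place of the isopropyl on the pyrazole, or a pyrazole bearing an amine, would begin to separate the two contributions.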